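Extending the Acid Side Chain of a Vitamin D Receptor Agonist

A few compounds are considered here, and "the series" means these few. Any claim that something is new, unique, unknown or untested is made for them only; others in the source may bear on it.

For the measured compounds named here, compound 1 `CCN(CC)CCCNC(=O)c1ccc(C(CC)(CC)c2ccc(C#CC(O)(CC)CC)c(C)c2)n1CC` gives the higher of the two numbers measured so far in an assay on cells for agonist activity at vitamin D3 receptor (Homo sapiens), read by microscopy (on this read-out higher numbers stand for an effect only at larger amounts of compound and lower numbers for an effect already at smaller amounts), where compound 1 gives 68.9 nM. Going by the values given here, compound 2 `CCn1c(C(=O)NCC(=O)O)ccc1C(CC)(CC)c1ccc(C#CC(O)(CC)CC)c(C)c1`, which carries an acid in place of the amine-bearing side chain, gives 9.36 nM; the step of a 7.4-fold lower number from compound 1 to compound 2 (0.87 log units; beyond the scatter) is the only measured step and is a clear gain. Compound 3 `CCn1c(C(=O)NCCC(=O)O)ccc1C(CC)(CC)c1ccc(C#CC(O)(CC)CC)c(C)c1` differs from compound 1 by carboxy in place of (diethylamino)methyl on a saturated chain carbon, two bonds along the chain from an amide-type nitrogen. Among the compounds with values here, this change resembles the one from compound 1 to compound 2, with the carboxy now sitting two bonds along the chain from an amide-type nitrogen, one more chain carbon than in compound 2. Because the step of a 7.4-fold lower number from compound 1 to compound 2 (0.87 log units; beyond the scatter) was clearly beyond the scatter, compound 3 is expected to show a gain of similar size, estimated as a 5.7-fold lower number from compound 1 to compound 3 (0.76 log units; beyond the scatter). Compound 3 is therefore expected to give about 12 nM, within a range of 4 nM to 35 nM.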

Compound 3, half-maximal effective concentration: 293 nM
Estimate against measurement, compound 3: 24-fold (1.39 log units) below; measured number outside the range, above it.
By their numbers in this assay, from the lowest: compound 2; then compound 1; then compound 3.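

In this assay a carboxy group at the end of this side chain does not bring a gain by itself: replacing (diethylamino)methyl with carboxy gives a 4.3-fold higher number from compound 1 to compound 3 (0.63 log units; beyond the scatter) and so moves the number the opposite way from the change that led to compound 2. The length of the chain carrying the acid matters strongly here, as carboxymethyl in place of carboxy gives a 31-fold higher number from compound 2 to compound 3 (1.50 log units; beyond the scatter) for just one more chain carbon. Nothing available explains this sharp dependence on chain length.

Three side chains cannot show whether the number keeps rising with a still longer chain ending in a carboxylic acid or changes in some other way. Going by these compounds, the effect of chain length on the amine side also remains open, for instance with a 2-(diethylamino)ethyl group on the amide nitrogen.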